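The source may report more compounds than this note shows. Statements on the series, on what has been measured and on what is new or still open speak of the compounds shown alone.

Working notes on the series. The two measured compounds share one core and differ at two places. Compound 1 `COC1CCN(CC(=O)N2CCN(c3sc(C(F)(F)F)nc3-c3nc4ccccc4[nH]3)C[C@H]2C)C1` gives 3380 nM in a functional assay on Venous blood for antagonist activity at C-X-C chemokine receptor type 3 (Homo sapiens), read by flow cytometry, with a stated time of 30 min, in the presence of a further agent that is not named here; a higher number here means a weaker inhibitor, a lower number a stronger inhibitor. Compound 2 `Cc1nc(C)n(CC(=O)N2CCN(c3sc(C(F)(F)F)nc3-c3nc4ccc(OC5COC5)cc4[nH]3)C[C@H]2C)n1` gives 1480 nM in this assay, the lower of the two numbers, and its gap to compound 1 lies beyond the scatter. Compound 3 `Cc1nc(C)n(CC(=O)N2CCN(c3sc(C(F)(F)F)nc3-c3nc4ccccc4[nH]3)C[C@H]2C)n1` is not yet measured; it differs from compound 2 by hydrogen in place of (oxetan-3-yl)oxy on an aromatic carbon. Among the compounds with values here, no measured pair isolates this change: compound 1 also lacks the (oxetan-3-yl)oxy group, but it carries a different amide side chain as well, so its value cannot be assigned to either change alone. A moderate weakening is expected for compound 3, at or near the edge of the scatter, giving an estimated 1.8-fold higher number from compound 2 to compound 3 (0.24 log units; within the scatter). Compound 3 is therefore expected to give about 2600 nM in this assay, with a range of 1000 nM to 6500 nM.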

Compound 3, half-maximal inhibitory concentration: 237 nM
Compound 3: middle estimate off by 11-fold (1.04 log units), on the high side; the whole stated range lies above it.
By their numbers in this assay, from the lowest: compound 3; then compound 2; then compound 1.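

Within the data shown here, compound 3 isolates the (oxetan-3-yl)oxy group for the first time: in this assay, replacing it with hydrogen on this aromatic carbon gives a 6.2-fold lower number from compound 2 to compound 3 (0.80 log units; beyond the scatter), so with the 3,5-dimethyl-1H-1,2,4-triazol-1-yl side chain held fixed, the inhibitor is stronger without this group. Compound 3 also isolates the side chain, where 3,5-dimethyl-1H-1,2,4-triazol-1-yl in place of 3-methoxypyrrolidin-1-yl gives a 14-fold lower number from compound 1 to compound 3 (1.15 log units; beyond the scatter), a large gain with the aromatic carbon bearing hydrogen. Nothing available explains either step.

What a methoxy group, a fluorine atom or a primary amine would give on this aromatic carbon remains open, as the compounds shown carry only hydrogen or (oxetan-3-yl)oxy there. Also open, from the compounds shown here alone, is whether the (oxetan-3-yl)oxy step holds with the 3-methoxypyrrolidin-1-yl side chain in place.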